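Replacing the 1-(trifluoromethyl)cyclopropyl group of compound 2

This account rests on a few compounds, and the source may have more. Where it says the series, first, only, none or still open, it means among the compounds named here.

In an ADME assay on microsomes from liver (Rattus norvegicus, strain Sprague-Dawley) for metabolic stability, read by HPLC, using NADPH, with stated times of 5 min and 60 min, tested at 10 uM (a higher number here means faster removal of the compound, a lower number slower removal), compound 1 `CCS(=O)(=O)Nc1ccc(CNC(=O)c2ccc(C(C)(C)C)cc2)c(Cl)c1` gives 28 mL.min-1.g-1. Compound 2 `CS(=O)(=O)Nc1ccc(CNC(=O)c2ccc(C3(C(F)(F)F)CC3)cc2)c(Cl)c1` gives 7.5 mL.min-1.g-1, the lower of the two numbers, and its gap to compound 1 lies beyond the scatter of repeat measurements. These two compounds differ in more than one place, so their gap cannot be tied to any single change.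

Compound 3 `CS(=O)(=O)Nc1ccc(CNC(=O)c2ccc(C34CC(C3)C4)cc2)c(Cl)c1` keeps the core of compound 2 but carries a new group: a group of 5 heavy atoms (5 carbon; 2 four-membered non-aromatic rings of carbon only) in place of a group of 7 heavy atoms (4 carbon, 3 fluorine; one three-membered non-aromatic ring of carbon only), on an aromatic carbon. The new group sits on an aromatic carbon, para to a large group. Among the compounds with values here, no measured pair shows this change alone, so any expectation here is loose. Within the data shown here, compound 1, at 28 mL.min-1.g-1, offers the only higher number for comparison, and a modest rise is expected. The expected change in this assay is an estimated 2.4-fold higher number from compound 2 to compound 3 (0.38 log units; beyond the scatter), a little beyond the scatter. For compound 3 the estimated value is 18 mL.min-1.g-1, with an expected range from 7 mL.min-1.g-1 to 45 mL.min-1.g-1.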

Compound 3, intrinsic clearance in microsomes: 17 mL.min-1.g-1
The estimate for compound 3 lay 1.1-fold (0.02 log units) above the measured number; measured number inside the range.
By their numbers in this assay, from the lowest: compound 2; then compounds 3 and 1 (each within the scatter of the next).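

In this assay, within the data shown here, the change from the 1-(trifluoromethyl)cyclopropyl group to the all-carbon group with two four-membered rings gives a 2.3-fold higher number from compound 2 to compound 3 (0.36 log units; beyond the scatter) and is the first step in this set that can be tied to a single change. It shows that the group on this aromatic carbon, para to a large group, affects the rate of removal, and that in this pair the 1-(trifluoromethyl)cyclopropyl group has the lower number. Nothing measured here explains the step.

Going by these compounds, both groups in this pair hold no hydrogen-bond donors or acceptors, so the effect of a morpholine ring, an amine or a carboxylic acid at this position remains open. On these data alone, compound 1 differs from both in more than one place, so the separate contribution of its tert-butyl group also remains unknown.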